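Swapping a butoxy for a diethylamino: expected lipophilicity shift

A few compounds are considered here, and "the series" means these few. Any claim that something is new, unique, unknown or untested is made for them only; others in the source may bear on it.

Three compounds sharing a branched chain with a doubly unsaturated ester have been measured in a physicochemical assay for lipophilicity; a lower number here means a more polar compound, a higher number a more lipophilic compound. Compound 1 `CC(/C=C/CC(C)CCCC(C)C)=C\C(=O)OC(C)C` gives 7.15, compound 2 `CC(/C=C/CC(C)CCCC(C)C)=C\C(=O)OCc1ccccc1` gives 7.87, and compound 3 `CCCCOC(=O)/C=C(C)/C=C/CC(C)CCCC(C)(C)OC` gives 6.62. Compound 3 thus stands lowest of the three; its nearest neighbour is compound 1, and compound 2 lies furthest above it. For the measured compounds named here, the one step between measured compounds that differ in a single place, a number 0.72 log units higher from compound 1 to compound 2 (beyond the scatter), concerns benzyl in place of isopropyl on an oxygen next to a carbonyl group and does not touch the part changed here.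

Compound 4 `CCN(CC)C(=O)/C=C(C)/C=C/CC(C)CCCC(C)(C)OC` differs from compound 3 in one place: diethylamino in place of butoxy on a carbonyl carbon. Going by the values given here, no measured step covers a change of this kind, so the expectation rests on the change alone. For compound 4 a downward step of a number 1.12 log units lower from compound 3 to compound 4 (beyond the scatter) is expected in this assay, beyond the scatter. The estimate for compound 4 is 5.5, within a range from 4.9 to 6.2.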

Compound 4, partition coefficient: 4.82
The estimate for compound 4 lay 0.68 log units above the measured number, outside the stated range (below it).
By their numbers in this assay, from the lowest: compound 4; then compound 3; then compound 1; then compound 2.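

In this assay, diethylamino in place of butoxy on a carbonyl carbon gives a number 1.80 log units lower from compound 3 to compound 4 (beyond the scatter) and so shows that this place in the molecule responds strongly to a change of the group on the carbonyl carbon. The size of the step stands out since both groups hold 5 heavy atoms and no ring, so a large shift appears with no change in those counts, and it runs the opposite way to the upward a number 0.72 log units higher from compound 1 to compound 2 (beyond the scatter). Nothing measured here explains why the step is this large.

Going by these compounds, whether a smaller amine such as dimethylamino, or a ring amine such as piperidinyl, on the same carbonyl carbon would give a step of similar size remains open. So does whether the same swap would shift the number as far on the core of compound 1.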